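Hydroxy for Hydrogen on a Methyl Group: An Estimate

The source may hold more compounds than are shown below. What is called first, only, known or untested is meant among the compounds shown, and "the series" means these compounds.

Compound 1, `CCCCc1cncc(OC[C@@H]2CCCN2C)c1`, gives 0.16 nM in an assay on membranes from brain for displacement of a labelled ligand from Neuronal acetylcholine receptor; alpha4/beta2 (Rattus norvegicus); on this read-out higher numbers stand for weaker inhibition and lower numbers for stronger inhibition.
Compound 2, `CCCCCCc1cncc(OC[C@@H]2CCCN2C)c1`, gives 0.32 nM in this assay.
Compound 3, `Cc1ccc(OC[C@@H]2CCCN2C)cn1`, gives 1.26 nM in this assay.

Among these three, compound 3 has the highest number; compound 2 stands nearest to it and compound 1 furthest, both with lower numbers, and both gaps lie beyond the scatter. Compound 4, `CN1CCC[C@H]1COc1ccc(CO)nc1`, has not yet been measured. It differs from compound 3 by hydroxy in place of hydrogen on a saturated chain carbon bound to an aromatic carbon. Among the compounds with values here, no measured step covers a change of this kind: the only step available, a 2.0-fold higher number from compound 1 to compound 2 (0.30 log units; within the scatter), concerns lengthening a saturated chain and lay within the scatter. With no direct guide, compound 4 is expected to give a modestly higher number than compound 3, a 2.4-fold higher number from compound 3 to compound 4 (0.38 log units; beyond the scatter), though a step no larger than the scatter cannot be ruled out. The estimate for compound 4 in this assay is 3 nM, with a range from 0.8 nM to 12 nM.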

Compound 4, inhibition constant: 97.4 nM
Compound 4: the middle estimate sits 32-fold (1.51 log units) below what was measured; measured number outside the range, above it.
By their numbers in this assay, from the lowest: compounds 1 and 2 (each within the scatter of the next); then compound 3; then compound 4.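

In this assay, going from methyl to hydroxymethyl on this saturated chain carbon bound to an aromatic carbon gives a 77-fold higher number from compound 3 to compound 4 (1.89 log units; beyond the scatter), so adding one oxygen here weakens inhibition sharply. Within the data shown here, the only earlier step, a 2.0-fold higher number from compound 1 to compound 2 (0.30 log units; within the scatter), lengthened a saturated chain and showed no change beyond the scatter. Nothing measured here explains the large shift.

On these data alone, whether a methoxy group, an amine or a carboxylic acid on this carbon would weaken inhibition as much remains open. So does whether hydroxy would have the same effect on the longer chains of compound 1 and compound 2.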